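This account rests on a few compounds, and the source may have more. Where it says the series, first, only, none or still open, it means among the compounds named here.

Working notes on the series. Compound 1 `C=C(Br)C(=O)Nc1ccc(/C=C/C(=O)c2ccccc2)cc1` gives 3100 nM in a functional assay on MOLT-4 cells (Homo sapiens) for antiproliferative activity, with a stated time of 48 h; on this read-out higher numbers stand for weaker inhibition and lower numbers for stronger inhibition. Compound 2 `C=C(Br)C(=O)Nc1ccc(/C=C/C(=O)c2ccc(OC)cc2)cc1` gives 1300 nM in this assay; the step of a 2.4-fold lower number from compound 1 to compound 2 (0.38 log units; beyond the scatter) corresponds to methoxy in place of hydrogen on an aromatic carbon. Compound 3 `C=C(Br)C(=O)Nc1ccc(C(=O)/C=C/c2ccccc2OC)cc1` gives 240 nM in this assay, the lowest number of the three measured; the difference between its core and the core of compound 1 is not broken down here. Compound 4 `C=C(Br)C(=O)Nc1ccc(C(=O)/C=C/c2ccc(OC)cc2OC)cc1` is not yet measured; from compound 3 it carries methoxy in place of hydrogen on an aromatic carbon. This is the same kind of change as from compound 1 to compound 2, but not the same: in compound 4 the new group sits meta to a methoxy group as well as para to a large group, whereas in compound 2 it sits only para to a large group. On the strength of the earlier step of a 2.4-fold lower number from compound 1 to compound 2 (0.38 log units; beyond the scatter), a similar modest step a 2.0-fold lower number from compound 3 to compound 4 (0.30 log units; within the scatter) is expected for compound 4, which is estimated at 120 nM in this assay, with a range from 40 nM to 400 nM.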

Compound 4, half-maximal inhibitory concentration: 1500 nM
Beside the measured number, compound 4's estimate is 13-fold (1.10 log units) below it, outside the stated range (above it).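

In this assay, methoxy in place of hydrogen on an aromatic carbon gives a 6.3-fold higher number from compound 3 to compound 4 (0.80 log units; beyond the scatter), so the lowering seen earlier does not carry over, and the same change cannot be treated as transferable between these cores: the same change on two cores in this assay, a 2.4-fold lower number (0.38 log units; beyond the scatter) from compound 1 to compound 2 and a 6.3-fold higher number (0.80 log units; beyond the scatter) from compound 3 to compound 4, 15-fold (1.17 log units) apart, beyond the scatter of two such steps This does not show whether the core or the methoxy group already present in compound 3 accounts for the difference, since the new group in compound 4 sits meta to a methoxy group as well as para to a large group, and the two cores differ as well. One pair of steps also gives no general rule for the series.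

From the compounds shown here alone, it remains open whether a hydroxyl group, an amine or a chlorine atom in the same place would follow the methoxy step from compound 3. Also open, going by these compounds, is how the methoxy group of compound 3 alone contributes to the number on that core.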